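This account rests on a few compounds, and the source may have more. Where it says the series, first, only, none or still open, it means among the compounds named here.

Of the compounds shown here, three with a shared core have been measured in an assay on Sf9 cells for inhibition of protein deacetylase HDAC6 (Homo sapiens), read by fluorescence, with a stated time of 40 min; on this read-out higher numbers stand for weaker inhibition and lower numbers for stronger inhibition. Compound 1 `Cc1cccc(-c2nc(CNc3ccc(C(=O)NO)cc3)n(-c3ccccc3)n2)c1` gives 281 nM, compound 2 `O=C(NO)c1ccc(NCc2nc(-c3ccccc3)nn2-c2ccccc2Cl)cc1` gives 669 nM, and compound 3 `O=C(NO)c1ccc(NCc2nc(-c3ccc(F)cc3)nn2-c2ccccc2)cc1` gives 115 nM. Compound 3 thus has the lowest number of the three, and its nearest neighbour is compound 1. Among the measured compounds shown here, the only single change measured so far is the step of a 2.4-fold lower number from compound 1 to compound 3 (0.39 log units; beyond the scatter), a modest gain that stands beyond the usual scatter. Compound 2 differs from compound 3 in more than one place, so its higher number can only be noted, not assigned to one change.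

The next compound, compound 4 `Cc1ccc(-c2nc(CNc3ccc(C(=O)NO)cc3)n(-c3ccccc3)n2)s1`, differs from compound 3 in one place: 5-methylthiophen-2-yl in place of 4-fluorophenyl on an aromatic carbon. The group enters on an aromatic carbon of the five-membered aromatic ring with three nitrogen atoms, the same place where compound 1 and compound 3 differ. Because that earlier change, a 2.4-fold lower number from compound 1 to compound 3 (0.39 log units; beyond the scatter), moved the number only modestly, a change of similar size at most is expected here, most likely towards a somewhat higher number, as a five-membered ring replaces the six-membered one that gave the lowest number. Compound 4 is therefore estimated at 200 nM, with a range of 70 nM to 600 nM, which means an expected step of a 1.7-fold higher number from compound 3 to compound 4 (0.24 log units; within the scatter).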

Compound 4, half-maximal inhibitory concentration: 30.6 nM
Compound 4: the middle estimate sits 6.5-fold (0.82 log units) above what was measured; measured number outside the range, below it.
By their numbers in this assay, from the lowest: compound 4; then compound 3; then compound 1; then compound 2.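

This position tolerates more than the first step could show: replacing a six-membered aromatic ring with a five-membered one containing a hetero atom does not cost activity, since 5-methylthiophen-2-yl gives a 3.8-fold lower number from compound 3 to compound 4 (0.57 log units; beyond the scatter). Against the 3-methylphenyl group the step is larger, at a 9.2-fold lower number from compound 1 to compound 4 (0.96 log units; beyond the scatter), so the three groups at this aromatic carbon spread the numbers more widely than compound 1 and compound 3 alone suggested. No measurement here explains why the number falls with this change.

On these data alone, it remains open whether the gain comes from the ring or from its methyl group, a question that a plain thiophen-2-yl or a furan-2-yl at this carbon could help to separate. As far as these compounds go, how a phenyl ring carrying an amine or a carboxylic acid would behave here also remains open.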